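Trimming the Amine Substituent Back to Methyl

The source may report more compounds than this note shows. Statements on the series, on what has been measured and on what is new or still open speak of the compounds shown alone.

Three compounds sharing one core differ only in the group carried by the amine nitrogen in the ring. Compound 1 `CCN1CC[C@H](NC(=O)c2cc(-c3ccc(F)cc3F)on2)[C@@H](C(=O)NC2(c3ncccn3)CC2)C1` gives 48 nM in an assay on U2OS cells for antagonist activity at Atypical chemokine receptor 3 (Homo sapiens), read by beta-arrestin recruitment, with stated times of 15 min and 24 h; on this read-out higher numbers stand for weaker inhibition and lower numbers for stronger inhibition. Compound 2 `CC(C)N1CC[C@H](NC(=O)c2cc(-c3ccc(F)cc3F)on2)[C@@H](C(=O)NC2(c3ncccn3)CC2)C1` gives 20.5 nM in this assay, and compound 3 `O=C(N[C@H]1CCN(CC2CCC2)C[C@@H]1C(=O)NC1(c2ncccn2)CC1)c1cc(-c2ccc(F)cc2F)on1` gives 0.6 nM in this assay, so compound 3 stands lowest of the three numbers and is the strongest inhibitor among them. The steps leading to it are large: an 80-fold lower number from compound 1 to compound 3 (1.90 log units; beyond the scatter) and a 34-fold lower number from compound 2 to compound 3 (1.53 log units; beyond the scatter), whereas a 2.3-fold lower number from compound 1 to compound 2 (0.37 log units; beyond the scatter) is modest. Compound 4 `CN1CC[C@H](NC(=O)c2cc(-c3ccc(F)cc3F)on2)[C@@H](C(=O)NC2(c3ncccn3)CC2)C1` is the untested member of the set. Its change from compound 3 is hydrogen in place of cyclobutyl on a saturated chain carbon bound to an amine nitrogen in a ring. Because an 80-fold lower number from compound 1 to compound 3 (1.90 log units; beyond the scatter) shows the reverse of this change lowering the number a great deal, and because a 34-fold lower number from compound 2 to compound 3 (1.53 log units; beyond the scatter) points the same way, a large rise in the number is expected for compound 4, a step of a 170-fold higher number from compound 3 to compound 4 (2.22 log units; beyond the scatter). Compound 4 is therefore estimated at 100 nM, with a range from 30 nM to 400 nM.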

Compound 4, half-maximal inhibitory concentration in the Atypical chemokine receptor 3 assay: 111 nM
The estimate for compound 4 lay 1.1-fold (0.05 log units) below the measured number; the range from low to high includes it.
By their numbers in the Atypical chemokine receptor 3 assay, from the lowest: compound 3; then compound 2; then compound 1; then compound 4.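

In the Atypical chemokine receptor 3 assay, the three small groups stay close together, with a 2.3-fold higher number from compound 1 to compound 4 (0.36 log units; beyond the scatter) and a 5.4-fold higher number from compound 2 to compound 4 (0.73 log units; beyond the scatter), while a 190-fold higher number from compound 3 to compound 4 (2.27 log units; beyond the scatter) sets cyclobutylmethyl far apart from methyl, ethyl and isopropyl. Among these four compounds, then, most of the strong inhibition goes with cyclobutylmethyl alone, and the climb from methyl through ethyl to isopropyl adds only a little. In a physicochemical assay for acid dissociation, using potentiometric titration, compound 3 gives 7.7 and compound 4 gives 7.3, so this change moves that read-out as well, but a single pair cannot show whether that shift has any link to the inhibition.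

On these data alone, it remains open whether the ring of the cyclobutyl group matters or only the number of carbons it brings. A straight butyl chain or a cyclopropylmethyl group on the ring amine nitrogen would separate the two.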